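The compounds below may be only part of what the source reports. "The series", "measured", "known", "first", "only" and "open" are said of these compounds alone.

Compound 1, `CCCNc1nnc(SCC(=O)N(Cc2cccc([N+](=O)[O-])c2)c2ccc(F)cc2)s1`, gives 25.1% in an assay on isolated protein for inhibition of Amine oxidase [flavin-containing] A (Homo sapiens), read by fluorescence and Amplex Red, with a stated time of 30 min, tested at 0.01 uM; on this read-out lower numbers stand for a weaker effect and higher numbers for a stronger effect at the one concentration tested.
Compound 2, `CC(C)Nc1nnc(SCC(=O)N(Cc2cccc([N+](=O)[O-])c2)c2ccc(F)cc2)s1`, gives 23.9% in this assay.

Of the two numbers in this assay, compound 1 holds the higher one, but the gap to compound 2 is a number 1.2 percentage points lower from compound 1 to compound 2 (within the scatter), so the two values cannot be told apart. For the measured compounds named here, the one measured step thus shows that swapping the shape of the alkyl group on the nitrogen on an aromatic ring, from propyl to isopropyl, leaves the read-out where it was.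

Compound 3, `CCNc1nnc(SCC(=O)N(Cc2cccc([N+](=O)[O-])c2)c2ccc(F)cc2)s1`, has not been measured in this assay. It differs from compound 1 by hydrogen in place of methyl on a saturated chain carbon, two bonds along the chain from a nitrogen on an aromatic ring. Going by the values given here, no measured pair shortens this chain, so the only step that bears on the question is the one from compound 1 to compound 2, and it was within the scatter. On that basis compound 3 is expected to sit close to compound 1, with a step of a number 1.1 percentage points lower from compound 1 to compound 3 (within the scatter) expected, none beyond the scatter in either direction. Compound 3 is therefore estimated at 24%, with a range from 12% to 36%.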

Compound 3, a percentage reported as inhibition, at one concentration (the size of the read-out at that concentration, not a potency): 30.3%
Compound 3: middle estimate off by 6.3 percentage points, on the low side, within the range that was stated.
By their numbers in this assay, from the lowest: compounds 2, 1 and 3 (each within the scatter of the next).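

Moving from propylamino to ethylamino gives in this assay a number 5.2 percentage points higher from compound 1 to compound 3 (within the scatter) and, starting from the isopropyl group, a number 6.4 percentage points higher from compound 2 to compound 3 (within the scatter) on the same nitrogen. Where the earlier compounds showed only that branching the chain left the read-out unchanged, these steps show that shortening it by one methyl also gives no step beyond the scatter, so propyl, isopropyl and ethyl on this nitrogen cannot be told apart at the one concentration tested. Nothing at hand speaks to why these values lie so close together.

What remains open is whether a butyl group, a cyclohexyl ring or a free amine on this position would move the read-out beyond the scatter, since the three groups shown are all small alkyl groups. As far as these compounds go, all three compounds also carry the same nitro group and fluorine elsewhere, so the effect of replacing either one remains unknown, and a read-out at one concentration gives no potency for any of them.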